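The source may hold more compounds than are shown below. What is called first, only, known or untested is meant among the compounds shown, and "the series" means these compounds.

Three compounds on a shared core differ only in the length of the chain attached to a triple-bonded carbon. In a functional assay on HEL cells (Homo sapiens) for cytotoxicity (on this read-out lower numbers stand for higher toxicity in this test and higher numbers for lower toxicity in this test), compound 1 `CCCCCCCCC#Cc1cc2cn([C@@H]3O[C@H](CO)[C@@H](O)[C@@H]3O)c(=O)nc2o1` gives 49000 nM, compound 2 `CCCCCCCCCCC#Cc1cc2cn([C@@H]3O[C@H](CO)[C@@H](O)[C@@H]3O)c(=O)nc2o1` gives 46000 nM, and compound 3 `CCCCCCC#Cc1cc2cn([C@@H]3O[C@H](CO)[C@@H](O)[C@@H]3O)c(=O)nc2o1` gives 133000 nM, the highest of the three numbers, with a 2.7-fold higher number from compound 1 to compound 3 (0.43 log units; beyond the scatter) and a 2.9-fold higher number from compound 2 to compound 3 (0.46 log units; beyond the scatter), whereas a 1.1-fold lower number from compound 1 to compound 2 (0.03 log units; within the scatter). Compound 4 `CCCCCCC#Cc1cc2cn([C@@H]3O[C@H](CO)[C@@H](O)[C@H]3O)c(=O)nc2o1` keeps the chain of compound 3 and alters something else: the two compounds have the same atoms and bonds and differ only in configuration as drawn: 1 of 4 stereo elements differ; a stereocentre at a saturated ring carbon is drawn S in compound 3 and R in compound 4. Going by the values given here, none of the measured steps involves a change in configuration, so no step bears on it directly, and the data offer no guide here. A step of little size is therefore expected, a 1.0-fold lower number from compound 3 to compound 4 (0.01 log units; within the scatter), with a wide range. Compound 4 is estimated at 130000 nM, between 40000 nM and 400000 nM.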

Compound 4, minimum cytotoxic concentration: >= 133000 nM
Compound 4: a limit, no number; the forecaster's own chance of this, stated with the estimate: 30%; middle value at least 1.0-fold (0.00 log units) from the limit.
By their numbers in this assay, from the lowest: compounds 2 and 1 (each within the scatter of the next); then compound 3.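

Changing the configuration at one saturated ring carbon from S to R gives, in this assay, a number no lower from compound 3 to compound 4 (the limit leaves the size open). Going by these compounds alone, until now only the chain had varied, so this is the first sign that this stereocentre can be switched without the number falling. For compound 4 the result is a limit and not a number: the limit of >= 133000 nM in this assay, at which 1 of the 4 values shown sits.

As far as these compounds go, the size of the gap stays open, as does whether the same switch would behave alike on the longer chains of compound 1 and compound 2. From the compounds shown here alone, the effect of an amine at this ring carbon also remains unknown.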